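The source may report more compounds than this note shows. Statements on the series, on what has been measured and on what is new or still open speak of the compounds shown alone.

Three compounds give a first view of how the shared core of compound 2 responds to what is attached to its amide-type nitrogen, all read in a functional assay on KYSE-450 cells (Homo sapiens) for inhibition, read by MTT assay, with a stated time of 48 h; a lower number here means a stronger inhibitor, a higher number a weaker inhibitor. Compound 1 `COc1ccc(CNc2cc(OC)c(OC)c(OC)c2)cc1C` carries no acyl group at all, and in this assay compound 1 gives 73800 nM. Compound 3 `C/C=C/C(=O)N(Cc1ccc(OC)c(Br)c1)c1cc(OC)c(OC)c(OC)c1` carries a crotonyl group and a bromine on the benzyl ring, and compound 3 gives 10500 nM. Compound 2 `C#CC(=O)N(Cc1ccc(OC)c(O)c1)c1cc(OC)c(OC)c(OC)c1`, with its ethynylcarbonyl group, gives 570 nM, the lowest of the three numbers and therefore the strongest inhibitor here, since its gaps to compound 3 and to compound 1 both lie beyond the usual scatter.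

Compound 4 `COc1ccc(CN(C(=O)CN=[N+]=[N-])c2cc(OC)c(OC)c(OC)c2)cc1O` is not yet measured. It differs from compound 2 in one place: azidomethyl in place of ethynyl on a carbonyl carbon.

Within the data shown here, no measured pair follows exactly this change, so the expectation rests on the spread seen so far: the one compound without the ethynylcarbonyl group and with an amide, compound 3, gives 10500 nM, well above compound 2. From that, the step from compound 2 to compound 4 is expected to be upward and sizeable, a 16-fold higher number from compound 2 to compound 4 (1.20 log units; beyond the scatter), in this assay. Compound 4 is thus estimated at 9000 nM, with a likely range from 2500 nM to 35000 nM.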

Compound 4, half-maximal inhibitory concentration: 160 nM
For compound 4 the middle estimate is 56-fold (1.75 log units) above the measured one; measured number below the stated range.
By their numbers in this assay, from the lowest: compound 4; then compound 2; then compound 3; then compound 1.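

At this carbonyl carbon, azidomethyl in place of ethynyl gives a real gain in this assay, with a 3.6-fold lower number from compound 2 to compound 4 (0.55 log units; beyond the scatter), so in this pair the ethynyl group and its triple bond are not needed for a low number. Among these compounds, this is the first comparison in the set that changes only one place, whereas the earlier compounds differed in more than one place at once, and it shows that this position accepts a group with more heavy atoms and a hydrogen-bond acceptor that ethynyl does not have. No measurement shown here offers an explanation for this step.

The compounds shown leave open whether the lower number belongs to the nitrogen atoms of the azido end or to the carbon that links them to the carbonyl, a question that a plain methyl or an aminomethyl group at the same carbonyl carbon could help to separate. They also leave open whether a longer chain ending in an azido group would push the number further down or back up.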